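The source may report more compounds than this note shows. Statements on the series, on what has been measured and on what is new or still open speak of the compounds shown alone.

For the measured compounds named here, compound 1 `CN1CCN(c2ccc(Nc3ncc4nc(Nc5ccc(F)cc5)n([C@H]5CCCN(S(=O)(=O)C6CC6)C5)c4n3)cc2)CC1` is one of two compounds measured in a functional assay on HCC827 cells (Homo sapiens) for antiproliferative activity, read by MTT assay, with a stated time of 72 h (on this read-out higher numbers stand for weaker inhibition and lower numbers for stronger inhibition), and in this assay compound 1 gives 8.6 nM. Its companion, compound 2 `CN1CCN(c2ccc(Nc3ncc4nc(Nc5ccccc5)n([C@@H]5CCN(S(=O)(=O)C6CC6)C5)c4n3)cc2)CC1`, gives 0.88 nM in this assay, the lower of the two numbers and beyond the scatter; the two structures differ in more than one place, so no single step between them is shown.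

The unmeasured compound 3 `CC(=O)Nc1cccc(-n2c(Nc3ccc(F)cc3)nc3cnc(Nc4ccc(N5CCN(C)CC5)cc4)nc32)c1` is derived from compound 1 by one change: 3-acetamidophenyl in place of 1-(cyclopropylsulfonyl)piperidin-3-yl on an aromatic nitrogen

Going by the values given here, no measured pair shows this same change on its own, so the direction of the step has to be judged on the two numbers above and on the change itself. Swapping a saturated, sulfonyl-bearing ring for a flat aromatic ring carrying an acetamido group is a substantial alteration at the ring nitrogen, and a modest weakening is expected, though one that could well fall within the scatter. Compound 3 is therefore expected to give about 20 nM in this assay, with a likely range from 4 nM to 100 nM, which corresponds to an expected step of a 2.3-fold higher number from compound 1 to compound 3 (0.37 log units; beyond the scatter).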

Compound 3, half-maximal inhibitory concentration: 10 nM
For compound 3 the middle estimate is 2.0-fold (0.30 log units) above the measured one, and the stated range covers the measured number.
By their numbers in this assay, from the lowest: compound 2; then compounds 1 and 3 (each within the scatter of the next).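

In this assay the change reads as a step (a 1.2-fold higher number from compound 1 to compound 3 (0.07 log units; within the scatter)), so on this aromatic nitrogen, next to the ring atom that bears the (4-fluorophenyl)amino group, 3-acetamidophenyl and 1-(cyclopropylsulfonyl)piperidin-3-yl cannot be told apart by this read-out. For this one pair, the number holds although the entering group has no sulfonyl, no non-aromatic ring and no defined stereocentre, and brings one six-membered aromatic ring and a hydrogen-bond donor, so the position accepts two very different groups on the core of compound 1. Nothing measured on these compounds accounts for the two groups reading alike.

As far as these compounds go, whether an unsubstituted phenyl, a 3-aminophenyl or a 3-carboxyphenyl would read the same on this nitrogen remains open, as does whether the acetamido group contributes anything to the number of compound 3. Compound 2 (0.88 nM) differs from compound 1 and from compound 3 in more than one place, so which of its features sets its number apart also stays unresolved.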